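From methyl to trifluoromethoxy on the amide aryl ring

This account rests on a few compounds, and the source may have more. Where it says the series, first, only, none or still open, it means among the compounds named here.

Two amides built on a shared core have been measured in a functional assay on cells for positive allosteric modulation of metabotropic glutamate receptor 5 (Rattus norvegicus), read by calcium flux (on this read-out higher numbers stand for an effect only at larger amounts of compound and lower numbers for an effect already at smaller amounts), so far. Compound 1 `O=C(Nc1cc(-c2ccccc2)nn1-c1ccccc1)c1cccc([N+](=O)[O-])c1` carries a 3-nitrophenyl group on the carbonyl carbon, and in this assay compound 1 gives 39 nM. Compound 2 `Cc1ccc(C(=O)Nc2cc(-c3ccccc3)nn2-c2ccccc2)cc1` carries a 4-methylphenyl group in that place instead, and in this assay compound 2 gives 64 nM. Among the compounds with values here, the only step between them, a 1.6-fold higher number from compound 1 to compound 2 (0.22 log units; within the scatter), is small, so compound 2 stands at the higher of the two numbers without being separable from compound 1 by this read-out.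

Compound 3 `O=C(Nc1cc(-c2ccccc2)nn1-c1ccccc1)c1ccc(OC(F)(F)F)cc1` is the next member of the series. Compared with compound 2, the change is trifluoromethoxy in place of methyl on an aromatic carbon, the new group sitting on an aromatic carbon of a six-membered aromatic ring of carbon only, para to a large group. Within the data shown here, only the step from compound 1 to compound 2 bears on this position, and it stayed within the scatter, so a change of the group on this ring is expected to move the number little. The step from compound 2 to compound 3 is therefore estimated at a 1.2-fold lower number from compound 2 to compound 3 (0.07 log units; within the scatter), and compound 3 is expected to give 55 nM in this assay, with a range from 18 nM to 170 nM.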

Compound 3, half-maximal effective concentration: 18 nM
The estimate for compound 3 lay 3.1-fold (0.49 log units) above the measured number, and the stated range covers the measured number.
By their numbers in this assay, from the lowest: compound 3; then compounds 1 and 2 (each within the scatter of the next).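

In this assay the exchange of methyl for trifluoromethoxy gives a 3.6-fold lower number from compound 2 to compound 3 (0.55 log units; beyond the scatter), a modest step but the first in this series to pass beyond the usual scatter. The earlier change on this ring, a 1.6-fold higher number from compound 1 to compound 2 (0.22 log units; within the scatter), stayed within the scatter and could have suggested that the number barely responds to the group there; this result shows that a group on an aromatic carbon, para to a large group, can shift the number downward. No measurement at hand explains the shift, so it cannot be assigned to any one feature of the entering group, and it rests on this single pair.

The compounds shown leave open which part of trifluoromethoxy matters, since neither a methoxy group nor a trifluoromethyl group appears in the same place to separate the contribution of the oxygen from that of the fluorines. They also leave open how far the trend extends, for instance to a longer chain such as an ethyl or propyl group, or to an amine or a carboxylic acid on this ring.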